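Dimethylamino for Acetyl on the Phenyl Ring

A few compounds are considered here, and "the series" means these few. Any claim that something is new, unique, unknown or untested is made for them only; others in the source may bear on it.

Of the compounds shown here, two built on one shared core have so far been tested in a functional assay on KM12 cells (Homo sapiens) for cytotoxicity, read by sulforhodamine B assay, with a stated time of 48 h, tested at 100 nM; a lower number here means a stronger effect, a higher number a weaker effect of the compound at the concentration tested. Compound 1 `COc1cc(C)cc(-c2c(-c3ccnc(-c4ccc(C(C)=O)cc4)c3)cnn2CC#N)c1` carries an acetyl group on its phenyl ring, and in this assay compound 1 gives 85%. Compound 2 `COc1cc(C)cc(-c2nn(CC#N)cc2-c2ccc(-c3cccc(C(C)=O)c3)nc2)c1` is an isomer of it, and in this assay compound 2 gives 75%. Of these two numbers, compound 1 holds the higher one, but the gap to compound 2 lies within the usual scatter of repeated measurements, so on these data the two compounds cannot be told apart.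

Compound 3 `COc1cc(C)cc(-c2c(-c3ccnc(-c4ccc(N(C)C)cc4)c3)cnn2CC#N)c1` has not yet been measured. It differs from compound 1 in one place: dimethylamino in place of acetyl on an aromatic carbon. Within the data shown here, no measured pair in this small set shows the outcome of such a change, so there is no step to lean on. Among the measured compounds shown here, with only two numbers, both near the upper end of the scale, the step in this assay is expected to be a number 5 percentage points lower from compound 1 to compound 3 (within the scatter), that is, nothing beyond the scatter in either direction. Compound 3 is therefore estimated at 80% in this assay, with a range from 55% to 100%.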

Compound 3, a percentage reported as activity, at one concentration (the size of the read-out at that concentration, not a potency): -36%
Compound 3: the middle estimate sits 116 percentage points above what was measured; the whole stated range lies above it.
By their numbers in this assay, from the lowest: compound 3; then compounds 2 and 1 (each within the scatter of the next).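

The change from 4-acetylphenyl to 4-(dimethylamino)phenyl gives, in this assay, a number 121 percentage points lower from compound 1 to compound 3 (beyond the scatter), which shows that the group on this aromatic carbon, para to a large group, has a strong hold on the read-out, something the two earlier compounds could not reveal because they share the acetyl group. A lower number here means a stronger effect, so dimethylamino at this position gives much the stronger effect of the pair, even though the two groups match in heavy-atom count and in the counts of hydrogen-bond donors and acceptors and neither carries a net charge; those counts therefore do not separate compound 1 from compound 3. Nothing in the available data explains why this exchange has such a large effect.

The compounds shown leave open whether the gain is specific to dimethylamino or would extend to a primary amine, a morpholine ring or a methoxy group at the same position. They also leave open whether dimethylamino would have a comparable effect on the isomeric arrangement of compound 2.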